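Working notes: from compound 2 to compound 3

The compounds below may be only part of what the source reports. "The series", "measured", "known", "first", "only" and "open" are said of these compounds alone.

Compound 2 `O=C([C@H]1CC[C@H](CO)CC1)N1CC[C@](c2ccc(C(F)(C(F)(F)F)C(F)(F)F)cc2)(S(=O)(=O)c2ccc(F)cc2)C1` is the starting point for this step. Among the compounds with values here, in an ADME assay on microsomes from liver (Mus musculus) for metabolic stability, with a stated time of 10 min (on this read-out higher numbers stand for a more stable compound and lower numbers for a less stable compound), compound 2 gives 63% as its only number, and a further entry for it carries no single value. Compound 1 `O=C1NC(=O)C2(CCC(C(=O)N3CC[C@](c4ccc(C(F)(C(F)(F)F)C(F)(F)F)cc4)(S(=O)(=O)c4ccc(F)cc4)C3)CC2)N1` reads higher in this assay at 81%; 82% (2 entries) with its repeat entries in close agreement.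

Compound 3 `O=C(N1CC[C@](c2ccc(C(F)(C(F)(F)F)C(F)(F)F)cc2)(S(=O)(=O)c2ccc(F)cc2)C1)C1(CO)CCS(=O)(=O)CC1` differs from compound 2 in one place, on a carbonyl carbon whose other neighbours are an amide-type nitrogen in a ring. There, 4-(hydroxymethyl)-1,1-dioxothian-4-yl stands in place of 4-(hydroxymethyl)cyclohexyl 4-(hydroxymethyl)-1,1-dioxothian-4-yl in place of 4-(hydroxymethyl)cyclohexyl on a carbonyl carbon and the rest of the structure is shared.

Within the data shown here, no measured step covers this change, so the expectation is loose. The reading of compound 1 at 81%; 82% (2 entries) shows only that values well over that of compound 2 occur among these two compounds. A modest upward move is expected in this assay with the estimated step of a number 11 percentage points higher from compound 2 to compound 3 (beyond the scatter) at about the edge of the usual scatter. Compound 3 is estimated at 74% (expected range 58% to 90%).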

Compound 3, percent of the compound remaining: 31%
Compound 3: the middle estimate sits 43 percentage points above what was measured; the measured number lies below the stated range.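

At the place on the carbonyl carbon, putting 4-(hydroxymethyl)-1,1-dioxothian-4-yl in place of 4-(hydroxymethyl)cyclohexyl matters strongly in this assay: the read-out gives a number 32 percentage points lower from compound 2 to compound 3 (beyond the scatter). This is the only measured step shown in the series, and it establishes that this position is not neutral for the read-out: with the shared core held constant, exchanging this group alone lowers the percent remaining, so a ring with a hetero atom and added oxygens here cannot be assumed to raise the number. The step is far larger than the disagreement between repeat entries of one compound, so it is not read as noise: the several entries of compound 1 in this assay, 81%; 82% (2 entries).

Whether the drop belongs to the 1,1-dioxothian ring itself or to the hydroxymethyl group being carried differently on the ring stays open; no compound shown changes one of these while holding the other fixed. Also open, on these data alone, is how a carboxylic acid, an amine or a tetrahydropyran ring at this place would read in this assay, and the numbers assign no mechanism to the loss.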